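A few compounds are considered here, and "the series" means these few. Any claim that something is new, unique, unknown or untested is made for them only; others in the source may bear on it.

Working notes on a set of four compounds sharing one core, varied only in the group on the carbonyl carbon. In a functional assay on the whole organism for inhibition, with Rattus norvegicus as the target, read by cytopathic effect and paw edema, at a dose of 100 mg/kg by the oral route (a higher number here means more inhibition at the dose given (going by the name of the read-out), a lower number less inhibition), compound 1 `CCOC(=O)c1c(O)c2cccnc2n(-c2ccccc2)c1=O` gives 15.5%. Compound 2 `O=C(NCc1ccccc1)c1c(O)c2cccnc2n(-c2ccccc2)c1=O` gives 11.3%. Compound 3 `CN(C)CCNC(=O)c1c(O)c2cccnc2n(-c2ccccc2)c1=O` gives 18.4%, the highest of the three numbers, though its steps from both others lie within the scatter: a number 2.9 percentage points higher from compound 1 to compound 3 (within the scatter) and a number 7.1 percentage points higher from compound 2 to compound 3 (within the scatter). Compound 4 `O=C(Nc1ccccc1)c1c(O)c2cccnc2n(-c2ccccc2)c1=O` is not yet measured; it carries phenyl in place of 2-(dimethylamino)ethyl on an amide-type nitrogen. Every measured step alters this same side chain, including a number 4.2 percentage points lower from compound 1 to compound 2 (within the scatter), and none moved beyond the scatter. For compound 4 the expected step is therefore a number 4.4 percentage points lower from compound 3 to compound 4 (within the scatter), none beyond the scatter. Compound 4 is estimated at 14%, with a range of 4% to 24%.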

Compound 4, a percentage reported as inhibition, in the whole organism at one dose (the size of the read-out at that dose, not a potency): -15%
The estimate for compound 4 lay 29 percentage points above the measured number; measured number below the stated range.
By their numbers in this assay, from the lowest: compound 4; then compounds 2, 1 and 3 (each within the scatter of the next).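

In this assay, among these compounds, the group on the carbonyl carbon can move the read-out beyond the scatter, which no earlier step did: anilino gives a number 33.4 percentage points lower from compound 3 to compound 4 (beyond the scatter), a number 30.5 percentage points lower from compound 1 to compound 4 (beyond the scatter) and a number 26.3 percentage points lower from compound 2 to compound 4 (beyond the scatter). The last step shows that phenyl on the amide-type nitrogen reads differently from benzyl, although benzyl also carries a phenyl ring. No available evidence bears on this fall. The compounds shown leave open whether any ring held on that nitrogen gives the same fall, as cyclohexyl would test, or only phenyl. On these data alone, whether a longer chain such as phenethyl behaves like benzyl also stays open.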